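A few compounds are considered here, and "the series" means these few. Any claim that something is new, unique, unknown or untested is made for them only; others in the source may bear on it.

Measured so far in a functional assay on LoVo cells (Homo sapiens) for inhibition, read by MTT assay, with a stated time of 72 h; on this read-out higher numbers stand for weaker inhibition and lower numbers for stronger inhibition

- compound 1 `COc1cc(NC(=O)/C=C/c2cccc(OCc3ccccc3)c2)cc(OC)c1OC` gives 21700 nM
- compound 2 `C=C(Br)C(=O)Nc1cccc(/C=C/C(=O)Nc2ccc(F)c(F)c2)c1` gives 540 nM
- compound 3 `C=C(Br)C(=O)Nc1cccc(/C=C/C(=O)Nc2ccc(Cl)cc2)c1` gives 5900 nM

Compound 1 shows the highest number of the three, which makes it the weakest inhibitor here, and its gaps to compound 2 and to compound 3 both lie beyond the scatter. The next compound, compound 4 `COc1cc(NC(=O)/C=C/c2cccc(N)c2)cc(OC)c1OC`, keeps the core of compound 1 but carries amino in place of benzyloxy on an aromatic carbon. Among the measured compounds shown here, no measured step covers this swap. For the measured compounds named here, the only step available (an 11-fold higher number from compound 2 to compound 3 (1.04 log units; beyond the scatter)) concerns another group, in a pair that differs from compound 1 in more than one place. That step shows that a single change can move the number a long way in this series, but it says nothing about the direction of the present change. A large shift therefore cannot be ruled out, yet nothing points either way, so no step beyond the scatter is expected in this assay and the range must stay wide. The expected step is small (a 1.4-fold lower number from compound 1 to compound 4 (0.16 log units; within the scatter)). The value estimated for compound 4 is 15000 nM (expected range 4000 nM to 60000 nM).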

Compound 4, half-maximal inhibitory concentration: 45200 nM
The estimate for compound 4 lay 3.0-fold (0.48 log units) below the measured number; the range from low to high includes it.
By their numbers in this assay, from the lowest: compound 2; then compound 3; then compound 1; then compound 4.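

In this assay, putting amino in place of benzyloxy on this aromatic carbon gives a 2.1-fold higher number from compound 1 to compound 4 (0.32 log units; beyond the scatter) and so shows that this position responds to the change, although the step is modest and only just clears the usual scatter. The swap takes away a group of 8 heavy atoms with its own aromatic ring and leaves a single nitrogen meta to a large group, and in this one pair the much smaller group goes with weaker inhibition, not stronger. Nothing measured here explains the direction of this step.

Both the loss of the ring and the arrival of the nitrogen happen in this single swap, so the compounds shown cannot tell which of the two moves the number, and a compound with methoxy or hydroxy on this carbon would help to separate them. As far as these compounds go, what an acetamide, a carboxylic acid or a longer chain such as phenethoxy would do at this position also remains open, as one pair gives no trend across groups.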